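Sulfonamide benzylamines: methoxy for bromine with a shorter linker

The source may hold more compounds than are shown below. What is called first, only, known or untested is meant among the compounds shown, and "the series" means these compounds.

Compound 1 `O=S(=O)(NCCCCNCc1ccc(Br)cc1)c1cc(C(F)(F)F)cc(C(F)(F)F)c1` is the reference point of this pair. In a functional assay on HT-29 cells (Homo sapiens) for inhibition, read by MTT assay, with a stated time of 72 h (on this read-out higher numbers stand for weaker inhibition of growth and lower numbers for stronger inhibition of growth), compound 1 gives 1600 nM, the lowest of the two numbers recorded so far. Compound 2 `COc1ccc(CNCCCNS(=O)(=O)c2cc(C(F)(F)F)cc(C(F)(F)F)c2)cc1OC` gives 2700 nM in this assay, a number that falls within the scatter of compound 1, so no order between the two can be read from these values. Compound 3 `COc1ccccc1CNCCCNS(=O)(=O)c1cc(C(F)(F)F)cc(C(F)(F)F)c1` has not been measured. Relative to compound 1 the change is (2-methoxybenzyl)amino in place of ((4-bromobenzyl)amino)methyl on a saturated chain carbon, three bonds along the chain from a sulfonamide nitrogen. Within the data shown here, no step between measured compounds has been recorded, so the size of this change has no direct precedent. The shorter linker of compound 3 is also present in compound 2, and compound 2 shows 2700 nM, close to compound 1. Compound 3 is therefore expected near the same level, estimated at 2500 nM with a range of 1000 nM to 6500 nM. The expected step of a 1.6-fold higher number from compound 1 to compound 3 (0.19 log units; within the scatter) is small, at most a modest weakening, and likely within the scatter.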

Compound 3, concentration for 50% growth inhibition: 12000 nM
Compound 3: middle estimate off by 4.8-fold (0.68 log units), on the low side; the measured number lies above the stated range.
By their numbers in this assay, from the lowest: compounds 1 and 2 (each within the scatter of the next); then compound 3.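

In this assay, the aryl group on the amine carries weight on the shorter chain: 2-methoxyphenyl in place of 3,4-dimethoxyphenyl gives a 4.4-fold higher number from compound 2 to compound 3 (0.65 log units; beyond the scatter) with the chain unchanged. The wider change, (2-methoxybenzyl)amino in place of ((4-bromobenzyl)amino)methyl, gives a 7.5-fold higher number from compound 1 to compound 3 (0.88 log units; beyond the scatter) and so shows that the closeness of the two earlier compounds does not extend to every substituted benzyl group on the shorter chain. No measurement at hand bears on the reason for either step.

The step from the longer chain still joins chain length and aryl group, and a 4-bromobenzyl group on the shorter chain would separate the two. Also open, from the compounds shown here alone, is how an unsubstituted benzyl group or a 4-methoxybenzyl group would stand against the 2-methoxybenzyl group of compound 3.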